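Swapping benzyl for furanylmethyl on the shared core

This account rests on a few compounds, and the source may have more. Where it says the series, first, only, none or still open, it means among the compounds named here.

Three compounds share one core and were tested in an ADME assay on GES1 cells (Homo sapiens) for antiproliferative activity, read by MTT assay, with a stated time of 72 h; a higher number here means a weaker inhibitor, a lower number a stronger inhibitor. Compound 1 `C/C(=N\Nc1nc(SCc2ccccc2)nc2c1nnn2Cc1ccccc1)c1ccccc1O` gives 56200 nM. Compound 2 `C#CCSc1nc(N/N=C/c2cc(OC)c(OC)c(OC)c2)c2nnn(Cc3ccccc3)c2n1` gives 25600 nM. Compound 3 `CCCSc1nc(N/N=C(\C)c2ccccc2O)c2nnn(Cc3ccccc3)c2n1` gives 32300 nM, which places it second highest of the three numbers; its nearest neighbour is compound 2 and its furthest is compound 1, both within the scatter of it. Going by the values given here, the only step between compounds differing in one place is a 1.7-fold lower number from compound 1 to compound 3 (0.24 log units; within the scatter), an ethyl in place of phenyl on a saturated chain carbon bound to a sulfur. Compound 4 `CCCSc1nc(N/N=C(\C)c2ccccc2O)c2nnn(Cc3ccco3)c2n1` differs from compound 3 by furan-2-yl in place of phenyl on a saturated chain carbon bound to an aromatic nitrogen. Among the compounds with values here, no measured step touches this position, so nothing in the data points one way or the other. The expectation for compound 4 is therefore no step beyond the scatter in this assay, written as a 1.0-fold lower number from compound 3 to compound 4 (0.00 log units; within the scatter). Compound 4 is estimated at 32000 nM, with a range from 12000 nM to 90000 nM.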

Compound 4, half-maximal inhibitory concentration: 33300 nM
Compound 4: the middle estimate sits 1.0-fold (0.02 log units) below what was measured; the range from low to high includes it.
By their numbers in this assay, from the lowest: compounds 2, 3, 4 and 1 (each within the scatter of the next, the first and the last beyond it).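

In this assay, replacing phenyl with furan-2-yl on a saturated chain carbon bound to an aromatic nitrogen gives a 1.0-fold higher number from compound 3 to compound 4 (0.01 log units; within the scatter). Going by these compounds alone, this is the first step read at this position, and it does not separate benzyl from (furan-2-yl)methyl in this assay, even though the entering group has a five-membered ring with one oxygen and one hydrogen-bond acceptor. Nothing available offers an explanation for this result.

As far as these compounds go, it remains open whether a different group at this position, such as an aminoethyl group, a carboxylic acid or a longer alkyl chain, would give a step beyond the scatter. Also open, from the compounds shown here alone, is whether the same swap would read alike with another group on the sulfur, such as the benzyl of compound 1.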